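Swapping Cyclohexyl for Oxan-4-yl on a Kinase Inhibitor

A few compounds are considered here, and "the series" means these few. Any claim that something is new, unique, unknown or untested is made for them only; others in the source may bear on it.

Compound 1, `CC(C)n1nc(-c2cc(C(C)(C)C)on2)c2c(N)ncnc21`, in an assay on isolated protein for inhibition of proto-oncogene tyrosine-protein kinase receptor Ret (Homo sapiens), read by radiometric assay and 33P incorporation, in the presence of a further agent that is not named here; a higher number here means a weaker inhibitor, a lower number a stronger inhibitor: 210 nM
Compound 2, `Nc1ncnc2c1c(-c1cc(C3CC3)on1)nn2C1CCCCC1`, in this assay: 2 nM
Compound 3, `CC(C)n1nc(/C=N/O)c2c(N)ncnc21`, in this assay: 4900 nM

Of these three, compound 2 carries the lowest number and is therefore the strongest inhibitor in this assay. Its nearest neighbour, compound 1, lies far above it, well beyond the scatter of repeated measurements, and compound 3 lies further still.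

Compound 4 is `Nc1ncnc2c1c(-c1cc(C3CC3)on1)nn2C1CCOCC1`. Compared with compound 2, the change is oxan-4-yl in place of cyclohexyl on an aromatic nitrogen. Among the compounds with values here, no measured pair here differs only in this way, so the size of the step rests on the change alone: one six-membered ring is replaced by another of the same size, with a single oxygen in place of a carbon. Such a step in this assay is expected to be small, at most a modest weakening, and quite possibly none beyond the scatter. Compound 4 is therefore expected to give about 4 nM, in the range 1.5 nM to 12 nM, which means an expected step of a 2.0-fold higher number from compound 2 to compound 4 (0.30 log units; within the scatter).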

Compound 4, half-maximal inhibitory concentration: 5 nM
For compound 4 the middle estimate is 1.3-fold (0.10 log units) below the measured one; low and high end bracket the measured number.
By their numbers in this assay, from the lowest: compound 2; then compound 4; then compound 1; then compound 3.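

Within the data shown here, this is the first pair in the set that differs in one place only, so it isolates the group on the aromatic nitrogen, which compounds 1 and 3 could not do because they differ from compound 2 in more than one place. In this assay, oxan-4-yl in place of cyclohexyl gives a 2.5-fold higher number from compound 2 to compound 4 (0.40 log units; beyond the scatter), a modest weakening that is beyond the scatter, and compound 4 stays at 5 nM, so this position accepts a ring oxygen at a small cost. Nothing measured here explains why the step has this size.

A ring with an amine nitrogen in place of the oxygen, or a carboxylic acid on the ring, could behave differently at this position. The step is also known only with the 5-cyclopropyl-1,2-oxazol-3-yl group in place, so it may differ with another group there.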